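Five-membered ring in place of six-membered ring: compound 4

This account rests on a few compounds, and the source may have more. Where it says the series, first, only, none or still open, it means among the compounds named here.

Of the compounds shown here, three sharing one core have been measured in a functional assay on HCT-116 cells (Homo sapiens) for inhibition, read by MTT assay, with a stated time of 72 h, tested at 20 uM; a higher number here means more inhibition at the concentration tested (going by the name of the read-out), a lower number less inhibition. Compound 1 `CN(c1ccc(Oc2ncnc3ccsc23)cc1)c1nccc(N2CCCC2)n1` gives 63.6%, compound 2 `CN(c1ccc(Oc2ncnc3ccsc23)cc1)c1nccc(N2CCCCC2)n1` gives 66.2%, and compound 3 `c1cc(N2CCCCC2)nc(Nc2ccc(Oc3ncnc4ccsc34)cc2)n1` gives 61.5%. All three numbers sit within the usual scatter of one another, so none of them can be separated from the others on these data.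

Two changes connect the measured compounds. From compound 2 to compound 1 the change is pyrrolidin-1-yl in place of piperidin-1-yl on an aromatic carbon, and the step it made in this assay is a number 2.6 percentage points lower from compound 2 to compound 1 (within the scatter). From compound 2 to compound 3 the change is hydrogen in place of methyl on a nitrogen on an aromatic ring, with a step of a number 4.7 percentage points lower from compound 2 to compound 3 (within the scatter).

Compound 4 `c1cc(N2CCCC2)nc(Nc2ccc(Oc3ncnc4ccsc34)cc2)n1` has not yet been measured. It is related to compound 3 by pyrrolidin-1-yl in place of piperidin-1-yl on an aromatic carbon, and the description of the place is the same word for word as for the change from compound 2 to compound 1, so it is called the same change. The cores of compound 3 and compound 2 differ by hydrogen in place of methyl on a nitrogen on an aromatic ring. On this basis the expected step in this assay is a number 2.5 percentage points lower from compound 3 to compound 4 (within the scatter), set beside a number 2.6 percentage points lower from compound 2 to compound 1 (within the scatter), and the expectation rests on the small size of that earlier step, which lay within the scatter. Compound 4 is therefore estimated at 59%, with a range from 47% to 70% expected.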

Compound 4, a percentage reported as inhibition, at one concentration (the size of the read-out at that concentration, not a potency): 22.2%
Compound 4: middle estimate off by 36.8 percentage points, on the high side; measured number below the stated range.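

In this assay, pyrrolidin-1-yl in place of piperidin-1-yl gives a number 39.3 percentage points lower from compound 3 to compound 4 (beyond the scatter), so this change does not carry over unchanged from the core of compound 2 to the core of compound 3: the same change on two cores in this assay, a number 2.6 percentage points lower (within the scatter) from compound 2 to compound 1 and a number 39.3 percentage points lower (beyond the scatter) from compound 3 to compound 4, 36.7 percentage points apart, beyond the scatter of two such steps. Hydrogen in place of methyl on the nitrogen behaves the same way, with a number 41.4 percentage points lower from compound 1 to compound 4 (beyond the scatter), and it too depends on the core it is made on: the same change on two cores in this assay, a number 4.7 percentage points lower (within the scatter) from compound 2 to compound 3 and a number 41.4 percentage points lower (beyond the scatter) from compound 1 to compound 4, 36.7 percentage points apart, beyond the scatter of two such steps. Across these four compounds the two changes therefore do not add up, and the large loss appears only where pyrrolidin-1-yl and the hydrogen on the nitrogen occur together in compound 4, although this shows neither why that happens nor how far it extends beyond these compounds, and it rests on a single read-out at one concentration rather than on a potency.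

The compounds shown leave open whether the loss in compound 4 is specific to pyrrolidin-1-yl or would also appear with another amine on the same aromatic carbon, such as morpholin-4-yl or azetidin-1-yl. They also leave open whether a longer chain on the nitrogen, such as ethyl, would behave like the methyl in compound 1 rather than like the hydrogen in compound 4.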